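This account rests on a few compounds, and the source may have more. Where it says the series, first, only, none or still open, it means among the compounds named here.

Measured compounds in a functional assay on MCF7 cells (Homo sapiens) for antiproliferative activity; on this read-out lower numbers stand for stronger inhibition and higher numbers for weaker inhibition:
compound 1 `COc1cc(Cc2nc3c(N)ncnc3n2CC2CCCO2)cc(OC)c1OC` gives 91200 nM
compound 2 `CCC(CC)Cn1c(Cc2cc(OC)c(OC)c(OC)c2)nc2c(N)ncnc21` gives 158000 nM
compound 3 `CC/C=C\Cn1c(Cc2cc(OC)c(OC)c(OC)c2)nc2c(N)ncnc21` gives 64600 nM

Compound 3 holds the lowest of the three numbers. Among the compounds with values here, its gap to compound 1 is within the scatter; only the step to compound 2 stands beyond it, at a 2.4-fold lower number from compound 2 to compound 3 (0.39 log units; beyond the scatter). The remaining steps are small: a 1.7-fold higher number from compound 1 to compound 2 (0.24 log units; within the scatter) and a 1.4-fold lower number from compound 1 to compound 3 (0.15 log units; within the scatter), both within the scatter.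

Compound 4 `CCn1c(Cc2cc(OC)c(OC)c(OC)c2)nc2c(N)ncnc21` is not yet measured. It differs from compound 3 by methyl in place of but-1-en-1-yl on a saturated chain carbon bound to an aromatic nitrogen. All three measured steps alter the same substituent on the saturated chain carbon bound to the aromatic nitrogen, and none of them moves this assay far, so the expected step is at most modest; the measured compounds give no case with so short a chain, and no direction can be read from them. With compound 2 carrying the bulkiest group and the highest number, a move toward a smaller group is not expected to raise the number much. Compound 4 is expected to give about 90000 nM, within 35000 nM to 230000 nM, an estimated step of a 1.4-fold higher number from compound 3 to compound 4 (0.14 log units; within the scatter) that is not expected to pass clearly beyond the scatter.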

Compound 4, half-maximal inhibitory concentration: 79400 nM
For compound 4 the middle estimate is 1.1-fold (0.05 log units) above the measured one; measured number inside the range.
By their numbers in this assay, from the lowest: compounds 3, 4, 1 and 2 (each within the scatter of the next, the first and the last beyond it).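

In this assay, methyl, the smallest group in the set, on the saturated chain carbon bound to an aromatic nitrogen stays within the scatter of all three earlier compounds (a 1.2-fold higher number from compound 3 to compound 4 (0.09 log units; within the scatter)) (a 1.1-fold lower number from compound 1 to compound 4 (0.06 log units; within the scatter)) (a 2.0-fold lower number from compound 2 to compound 4 (0.30 log units; within the scatter)). Within the data shown here, the double bond of but-1-en-1-yl and the ring of oxolan-2-yl are therefore not needed to hold the number at this level, which the earlier compounds could not show without so short a group. Among the four compounds, the only step beyond the scatter remains the one between pentan-3-yl and but-1-en-1-yl.

No supporting data explain why these numbers lie so close together. As far as these compounds go, whether an amine, a carboxylic acid or a longer chain at this position would move the number clearly away from these values remains open.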